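This account rests on a few compounds, and the source may have more. Where it says the series, first, only, none or still open, it means among the compounds named here.

Working notes on the series in a functional assay, with a stated time of 150 min, tested at 35 ug/mL; a lower number here means a weaker effect, a higher number a stronger effect of the compound at the concentration tested.

Two compounds have been run so far. Compound 1, `COC(=O)c1c(Nc2ccc(Cl)cc2)sc(C(=O)c2ccc(OC)cc2)c1C`, is reported in this assay only as "not active" (no number reported), without a number. Within the data shown here, compound 2, `COc1ccc(Nc2sc(C(=O)c3ccc(OC)cc3)c(C)c2C(=O)O)cc1`, gives 51% in this assay, which is the only number in the set; the one further entry, compound 1, carries no single number. Compound 1 and compound 2 differ in more than one place, so nothing can be read from their pair beyond what the two entries show.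

The next compound, compound 3, `COc1ccc(C(=O)c2sc(Nc3ccc(Cl)cc3)c(C(=O)O)c2C)cc1`, is unmeasured. It differs from compound 2 in one place: chloro in place of methoxy on an aromatic carbon. Among the measured compounds shown here, no step between two measured compounds isolates this change, and the only other compound in the set, compound 1, carries the same chloro group but an ester and is reported without a number, so there is no precedent for the direction of the step. A moderate drop, possibly beyond the scatter, is the working expectation, a number 13 percentage points lower from compound 2 to compound 3 (beyond the scatter).

For compound 3, the estimate in this assay is 38%, with a range from 10% to 65%, and a fair chance that it is reported only as not active.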

Compound 3, a percentage reported as activity, at one concentration (the size of the read-out at that concentration, not a potency): "not active" (no number reported)
Compound 3: no number reported, and the estimate cannot be compared.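

In this assay, among these compounds, compound 3 is reported only as "not active" (no number reported), so no step from compound 2 to compound 3 can be read. No measured evidence bears on this result. The compounds shown leave open how large the effect of replacing methoxy with chloro is, as compound 2 alone carries a number.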